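A Single Fluoro Added to Compound 2

This account rests on a few compounds, and the source may have more. Where it says the series, first, only, none or still open, it means among the compounds named here.

The study measures growth inhibition in a functional assay on PC-3 cells (Homo sapiens) for cytotoxicity, read by MTT assay, with a stated time of 72 h; on this read-out lower numbers stand for stronger inhibition and higher numbers for weaker inhibition. Of the compounds shown here, two have numbers so far. Compound 1 `Cc1cc(=O)n(-c2ccc(Br)cc2F)nc1C(=O)Nc1ccc(Oc2ncnc3[nH]ccc23)cc1` gives 2730 nM in this assay. Compound 2 `Cc1cc(=O)n(-c2cccc(C(F)(F)F)c2)nc1C(=O)Nc1ccc(Oc2ncnc3[nH]ccc23)cc1` gives 3460 nM in this assay. Going by the values given here, the one step between them, a 1.3-fold higher number from compound 1 to compound 2 (0.10 log units; within the scatter), exchanges the substituent on the aromatic nitrogen and stays within the scatter. Compound 2 thus stands at the upper of the two numbers, but compound 1 lies within the scatter of it, so the two cannot be told apart.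

Compound 3 `Cc1cc(=O)n(-c2cccc(C(F)(F)F)c2)nc1C(=O)Nc1ccc(Oc2ncnc3[nH]ccc23)c(F)c1` has not been measured. It differs from compound 2 by fluoro in place of hydrogen on an aromatic carbon. Among the compounds with values here, no measured step bears on this change: the only step available concerns the substituent on the aromatic nitrogen and leaves the ring that here gains a fluoro untouched. With nothing pointing in either direction, a step of a 1.2-fold lower number from compound 2 to compound 3 (0.06 log units; within the scatter) is expected, a change no larger than the scatter. Compound 3 is accordingly estimated at 3000 nM, with a range from 1200 nM to 8000 nM.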

Compound 3, half-maximal inhibitory concentration: 15600 nM
Compound 3: middle estimate off by 5.2-fold (0.72 log units), on the low side, outside the stated range (above it).
By their numbers in this assay, from the lowest: compounds 1 and 2 (each within the scatter of the next); then compound 3.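

In this assay the change gives a 4.5-fold higher number from compound 2 to compound 3 (0.65 log units; beyond the scatter), the first step among these compounds that lies beyond the scatter. It shows that this aromatic carbon, on a six-membered aromatic ring of carbon only, ortho to a large group and meta to a large group, is not indifferent to substitution: the entry of fluoro, a single heavy atom in place of hydrogen, is enough to weaken inhibition modestly, whereas the exchange of the whole substituent on the aromatic nitrogen between compound 1 and compound 2 stayed within the scatter. No measurement at hand accounts for this loss.

The compounds shown leave open whether the loss is particular to fluoro or would also follow from another group on this carbon, such as chloro, methyl or an amine. They also leave open whether fluoro at this place would cost as much with the 4-bromo-2-fluorophenyl of compound 1 on the aromatic nitrogen as it does with the 3-(trifluoromethyl)phenyl of compound 2.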